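Hydroxy in place of carbamoyl on the shared core

This account rests on a few compounds, and the source may have more. Where it says the series, first, only, none or still open, it means among the compounds named here.

Compound 2 `NC(=O)c1cncc(N2CCCNCC2)c1` gives 12900 nM in a functional assay on HEK293 cells for agonist activity at Neuronal acetylcholine receptor; alpha4/beta2 (Homo sapiens), read by FLIPR and calcium flux (on this read-out higher numbers stand for an effect only at larger amounts of compound and lower numbers for an effect already at smaller amounts), the highest of the two numbers shown; its nearest neighbour, compound 1 `COc1cncc(N2CCCNCC2)c1`, gives 1410 nM. Compound 3 `Oc1cncc(N2CCCNCC2)c1` differs from compound 2 by hydroxy in place of carbamoyl on an aromatic carbon. Within the data shown here, no measured step covers this exact change; the only step known is a 9.1-fold higher number from compound 1 to compound 2 (0.96 log units; beyond the scatter), where a carbamoyl entered for a methoxy. Since that change raised the number, its removal is expected to lower it, so a step of a 4.3-fold lower number from compound 2 to compound 3 (0.63 log units; beyond the scatter) is expected. Compound 3 is therefore estimated at 3000 nM, with a range from 800 nM to 12000 nM.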

Compound 3, half-maximal effective concentration: 141 nM
The estimate for compound 3 lay 21-fold (1.33 log units) above the measured number, and the stated range ends above it.
By their numbers in this assay, from the lowest: compound 3; then compound 1; then compound 2.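

In this assay, this position on the aromatic carbon proves more sensitive than the first pair showed: hydroxy in place of carbamoyl gives a 91-fold lower number from compound 2 to compound 3 (1.96 log units; beyond the scatter). Removing only the methyl from the oxygen also matters, with a 10-fold lower number from compound 1 to compound 3 (1.00 log units; beyond the scatter), so compound 3 has the lowest number of the three, and both of its steps lie beyond the scatter. Nothing measured here accounts for this order. As far as these compounds go, whether an amine or a carboxylic acid at this position would give a low or a high number stays open. So does the effect of a longer chain on the oxygen.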